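The source may report more compounds than this note shows. Statements on the series, on what has been measured and on what is new or still open speak of the compounds shown alone.

Measured in a physicochemical assay for lipophilicity, using the shake flask method, in phosphate buffer, measured as octanol-water partition, with a stated time of 30 min, at pH 7.4; on this read-out lower numbers stand for lower lipophilicity and higher numbers for higher lipophilicity:
- compound 1 `O=C(Nc1ccccc1)c1cnc(NCc2c(F)ccc3c2CCO3)n2cnnc12` gives 4.1
- compound 2 `CN(C)Cc1ccc(C(=O)Nc2cnc(NCc3c(F)ccc4c3CCO4)n3cnnc23)cc1` gives 1.8
- compound 3 `CN(c1ccccc1)c1cnc(NCc2c(F)ccc3c2CCO3)n2cnnc12` gives 3.6

Compound 3 stands second highest of the three, under compound 1 and over compound 2, with both gaps beyond the scatter. The next change leads to compound 4 `O=C(Nc1cnc(NCc2c(F)ccc3c2CCO3)n2cnnc12)c1ccccc1` and puts benzamido in place of methyl(phenyl)amino on an aromatic carbon. For the measured compounds named here, the one measured step bearing on it is a number 0.50 log units lower from compound 1 to compound 3 (beyond the scatter), which left phenylcarbamoyl for the same methyl(phenyl)amino. Going by the values given here, compound 4 regains a carbonyl and an amide hydrogen, so a small rise in this assay is expected, no larger than that step and possibly within the scatter. Among the compounds with values here, no measured step links compound 2 to this change, so it carries little weight. The estimated step is a number 0.30 log units higher from compound 3 to compound 4 (within the scatter). The expected value for compound 4 is 3.9, within an estimated range of 3.4 to 4.4.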

Compound 4, distribution coefficient: 3
Beside the measured number, compound 4's estimate is 0.90 log units above it, and the stated range ends above it.
By their numbers in this assay, from the lowest: compound 2; then compound 4; then compound 3; then compound 1.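

In this assay, benzamido on this aromatic carbon gives a number 0.60 log units lower from compound 3 to compound 4 (beyond the scatter) and a number 1.10 log units lower from compound 1 to compound 4 (beyond the scatter), so benzamido and phenylcarbamoyl do not read alike at this position. With hydrogen in place of (dimethylamino)methyl, the step is a number 1.20 log units higher from compound 2 to compound 4 (beyond the scatter), which leaves compound 2 the lowest of the four. No supporting measurement bears on these steps.

Open, on these data alone, is how a benzamido group carrying a carboxylic acid or a morpholine in place of (dimethylamino)methyl would read in this assay.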